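This account rests on a few compounds, and the source may have more. Where it says the series, first, only, none or still open, it means among the compounds named here.

Within the data shown here, compound 3 `CCCCN(C(=O)c1ccc(C(F)(F)F)cc1)c1nnc(-c2ccc(CN(C)C)cc2)s1` gives 478 uL/min in an ADME assay on microsomes from liver (Mus musculus) for metabolic stability, read by LC-MS, tested at 0.5 uM (a higher number here means faster removal of the compound, a lower number slower removal), the highest of the three numbers measured so far. Compound 1 `CCCCN(C(=O)c1ccc(C(F)(F)F)cc1)c1nnc(-c2ccc(S(=O)(=O)NCCC(=O)O)cc2)s1` gives 137 uL/min, and compound 2 `CCCCN(C(=O)c1ccc(C(F)(F)F)cc1)c1nnc(-c2cccc3[nH]ccc23)s1` gives 63 uL/min. Both measured steps lead into compound 3: a 3.5-fold higher number from compound 1 to compound 3 (0.54 log units; beyond the scatter), and a 7.6-fold higher number from compound 2 to compound 3 (0.88 log units; beyond the scatter). In each case a change of the group carried by the shared core raised the number beyond the scatter, so the substituent on that outer ring clearly matters here.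

Compound 4 `CCCCN(C(=O)c1ccc(C(F)(F)F)cc1)c1nnc(-c2ccc(CO)cc2)s1` differs from compound 3 in one place: hydroxy in place of dimethylamino on a saturated chain carbon bound to an aromatic carbon. Among the measured compounds shown here, no measured pair shows this particular exchange, so the two steps into compound 3 serve only as a guide to how much the number can move when that group changes. Since every measured alternative to the dimethylamino group of compound 3 gave a lower number, a lower number for compound 4 is expected, of modest size, a 2.4-fold lower number from compound 3 to compound 4 (0.38 log units; beyond the scatter). Compound 4 is therefore estimated at 200 uL/min, with a likely range from 80 uL/min to 450 uL/min.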

Compound 4, intrinsic clearance in a liver preparation (reported as CLH), per the amount of preparation that the assay uses: 712 uL/min
Estimate against measurement, compound 4: 3.6-fold (0.55 log units) below; the whole stated range lies below it.
By their numbers in this assay, from the lowest: compound 2; then compound 1; then compounds 3 and 4 (each within the scatter of the next).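

In this assay, putting hydroxy in place of dimethylamino on this saturated chain carbon bound to an aromatic carbon does not separate the two compounds (a 1.5-fold higher number from compound 3 to compound 4 (0.17 log units; within the scatter)), so the nitrogen and its two carbons are not needed for a number this high. Compound 4 also stands well clear of the compounds carrying other groups on the outer ring (an 11-fold higher number from compound 2 to compound 4 (1.05 log units; beyond the scatter); a 5.2-fold higher number from compound 1 to compound 4 (0.72 log units; beyond the scatter)), so both groups tried on this chain carbon share the high end of the series. Nothing measured here explains why the numbers fall this way.

Still open, on these data alone, is whether a methoxy group, a primary amine or a longer chain on this carbon would keep the number as high. Also open, as far as these compounds go, is how much the butyl chain and the trifluoromethyl group, common to all four compounds, contribute to it.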